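The source may report more compounds than this note shows. Statements on the series, on what has been measured and on what is new or still open speak of the compounds shown alone.

Compound 1, `Cc1ccc2nc(Nc3ccnc(Nc4ccc(S(C)(=O)=O)cc4)n3)sc2c1`, carries the shared core of this small set, and in a functional assay on HeLa cells (Homo sapiens) for antiproliferative activity, read by MTT assay, with a stated time of 48 h (on this read-out lower numbers stand for stronger inhibition and higher numbers for weaker inhibition), compound 1 gives 2300 nM. Its nearest neighbour on the numbers shown is compound 2, `COc1ccc2nc(Nc3ccnc(Nc4ccc(S(C)(=O)=O)cc4)n3)sc2c1`, which in this assay gives 4130 nM; the step of a 1.8-fold higher number from compound 1 to compound 2 (0.25 log units; within the scatter) is too small to count as a change, so the two compounds stand together within the usual scatter. Compound 3, `Cc1cnc(Nc2ccc(S(C)(=O)=O)cc2)nc1Nc1nc2ccc(F)cc2s1`, differs from the others in more than one place. For compound 3, this assay reports only a limit, > 50000 nM, which is the limit of > 50000 nM in this assay, at which 1 of the 3 values shown sits.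

Compound 4, `Cc1ccc2nc(Nc3ccnc(Nc4ccc(S(N)(=O)=O)cc4)n3)sc2c1`, has not yet been measured. It differs from compound 1 in one place: amino in place of methyl on a sulfonyl sulfur. Among the measured compounds shown here, no measured step touches the sulfonyl sulfur: the single-point step from compound 1 to compound 2 lies on an aromatic carbon and stays within the scatter, while compound 3 is not a one-step comparison and gives only a limit. The data therefore offer no ground for a shift in either direction beyond the scatter. Compound 4 is expected to give about 2500 nM, between 800 nM and 8000 nM. The step of a 1.1-fold higher number from compound 1 to compound 4 (0.04 log units; within the scatter) is thus expected to be essentially flat.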

Compound 4, half-maximal inhibitory concentration: 660 nM
Beside the measured number, compound 4's estimate is 3.8-fold (0.58 log units) above it, outside the stated range (below it).
By their numbers in this assay, from the lowest: compound 4; then compounds 1 and 2 (each within the scatter of the next). At a limit, above all of these: compound 3.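

Amino in place of methyl on a sulfonyl sulfur gives a 3.5-fold lower number from compound 1 to compound 4 (0.54 log units; beyond the scatter) in this assay, and this is the first single-place step in the set to lie beyond the scatter, although it is modest. The only earlier single-place step, on an aromatic carbon, was a 1.8-fold higher number from compound 1 to compound 2 (0.25 log units; within the scatter), so the series had not yet shown that one change could move the number measurably; the sulfonyl sulfur is a place where it can, and the lower number here comes with the move from methylsulfonyl to sulfamoyl, which brings in one hydrogen-bond donor. Among the compounds shown here, nothing in the evidence at hand bears on why the number moves at this place, and the single step cannot separate the donor from any other difference between methyl and amino.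

The compounds shown leave open whether a methylamino or dimethylamino group on the same sulfonyl sulfur, or a carboxylic acid in place of the whole sulfamoyl group, would keep this shift. They also leave open whether amino in place of methyl at this sulfur gives a similar step on the core of compound 2.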